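The compounds below may be only part of what the source reports. "The series", "measured", "known", "first", "only" and "open" are said of these compounds alone.

In an ADME assay on microsomes from liver (Rattus norvegicus) for metabolic stability, with a stated time of 30 min (on this read-out higher numbers stand for a more stable compound and lower numbers for a less stable compound), compound 1 (`COc1c(C(=O)Nc2ccc(NS(C)(=O)=O)cc2)cc(N2CCC(=O)NC2=O)cc1C(C)(C)C`) gives > 85% as its reading, which is a limit of the assay and not a number. Compound 1 therefore stands at that limit (the limit of > 85% in this assay, at which 1 of the 3 values shown sits). Two relatives read lower: compound 2 (`COc1c(CNc2ccc(NS(C)(=O)=O)cc2)cc(N2CCC(=O)NC2=O)cc1C(C)(C)C`) gives 58% here, and compound 3 (`COc1c(/C=C(\C)c2ccc([N+](=O)[O-])cc2)cc(N2CCC(=O)NC2=O)cc1C(C)(C)C`) gives 36.5% here.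

Compound 4 (`COc1c(C(=O)N(C)c2ccc(NS(C)(=O)=O)cc2)cc(N2CCC(=O)NC2=O)cc1C(C)(C)C`) is compound 1 with methyl in place of hydrogen on an amide-type nitrogen. Among the compounds with values here, no measured pair shows this change on its own, so its effect in this assay can only be judged loosely. The reading of compound 2 (58%) shows that a relative of compound 1 can be clearly less stable, so a moderate fall beyond the usual scatter is expected rather than no change. The estimated size of this fall is a number at least 15 percentage points lower from compound 1 to compound 4 (beyond the scatter) on the percent scale. For compound 4 the estimate is 70% with an expected range from 48% to 88% for repeat readings.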

Compound 4, percent of the compound remaining in the liver assay: 83%
Compound 4: middle estimate off by 13 percentage points, on the low side, within the range that was stated.
By their numbers in the liver assay, from the lowest: compound 3; then compound 2; then compound 4. At a limit, above all of these: compound 1.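

Within the data shown here, putting methyl in place of hydrogen on the amide-type nitrogen is the first change that can be read on its own, and in the liver assay it gives a number at least 2 percentage points lower from compound 1 to compound 4 (that floor lies within the scatter); the reading of compound 1 there is a limit of the assay, so the true size of this step stays unknown. In a physicochemical assay for solubility, at pH 7.2 (a lower number here means a less soluble compound, a higher number a more soluble compound), the same change comes with a large rise in measured solubility: the measured solubility of compound 1, < 1500 nM, and of compound 4, > 50000 nM, an at least 33-fold higher number (1.52 log units; beyond the scatter) In the physicochemical assay compound 1 gives < 1500 nM, which is a limit of the assay. In the physicochemical assay compound 4 gives > 50000 nM, which is also a limit of the assay. From the compounds shown here alone, the full size of the rise therefore also stays unknown.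

Going by these compounds, it remains open whether a larger group on this nitrogen, such as ethyl or a longer chain, would give similar readings in both assays. The same question holds for a chain ending in an amine or a carboxylic acid.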